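A fluorophenyl-to-carboxyphenyl exchange on a cytotoxic diterpenoid core

The source may hold more compounds than are shown below. What is called first, only, known or untested is meant among the compounds shown, and "the series" means these compounds.

Compound 1 `C=C1[C@@H](OC(C)=O)C[C@@H]2[C@](C)(CO[Si](C)(C)C(C)(C)C)[C@H](OC(C)=O)CC[C@@]2(C)[C@@H]1C[C@@H](Nc1ccccc1F)C1=CCOC1=O`: 3710 nM
Compound 2 `C=C1CC[C@@H]2[C@](C)(CO[Si](C)(C)C(C)(C)C)[C@H](OC(C)=O)CC[C@@]2(C)[C@@H]1C/C=C1/C(=O)OC[C@H]1OC(C)=O`: 4690 nM

Of the compounds shown here, two have been measured in a functional assay on HT-29 cells (Homo sapiens) for cytotoxicity, read by sulforhodamine B assay; on this read-out higher numbers stand for weaker inhibition and lower numbers for stronger inhibition. Compound 1 gives 3710 nM, the lower of the two numbers, while compound 2 gives 4690 nM; the gap between them lies within the usual scatter, so the two compounds cannot be told apart on these data. For the measured compounds named here, no pair of measured compounds differs in a single place, so no measured step is available to lean on.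

Compound 3 `C=C1[C@@H](OC(C)=O)C[C@@H]2[C@](C)(CO[Si](C)(C)C(C)(C)C)[C@H](OC(C)=O)CC[C@@]2(C)[C@@H]1C[C@@H](Nc1ccc(C(=O)O)cc1)C1=CCOC1=O` has not been measured. It differs from compound 1 in one place: 4-carboxyphenyl in place of 2-fluorophenyl on an amine nitrogen. Without any measured step of this kind, the size of the change in this assay rests on general expectation only. A modest weakening is expected, with the step of a 2.2-fold higher number from compound 1 to compound 3 (0.33 log units; beyond the scatter) expected to lie just beyond the scatter, though a result within the scatter would not be surprising. On that basis, compound 3 is estimated to give 8000 nM in this assay, with a range from 2500 nM to 25000 nM.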

Compound 3, half-maximal inhibitory concentration: 4630 nM
Compound 3: middle estimate off by 1.7-fold (0.24 log units), on the high side; low and high end bracket the measured number.
By their numbers in this assay, from the lowest: compounds 1, 3 and 2 (each within the scatter of the next).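

In this assay, the exchange of 2-fluorophenyl for 4-carboxyphenyl on the amine nitrogen gives a 1.2-fold higher number from compound 1 to compound 3 (0.10 log units; within the scatter) and so compound 3 cannot be told apart from compound 1 on this read-out. For the compounds shown here, this is the first measured step at this place on the shared core, which the earlier comparison of compound 1 with compound 2 could not supply, as those two differ in more than one place. It shows that the aryl group on this nitrogen can lose its fluorine and gain a carboxylic acid, with its added hydrogen-bond donor and acceptor, while the number stays within the scatter, though no measurement here explains that outcome.

The compounds shown leave open whether a different group on this nitrogen, such as a pyridine ring, a cyclohexyl ring or a simple alkyl chain, would move the number beyond the scatter. They also leave open whether an amide or a primary amine in place of the carboxylic acid on the phenyl ring would give a number that can be told apart from that of compound 3.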